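The source may report more compounds than this note shows. Statements on the series, on what has been measured and on what is new or still open speak of the compounds shown alone.

Measured so far in an ADME assay on Vero cells (Chlorocebus sabaeus) for cytotoxicity, read by MTT assay, with a stated time of 72 h; a lower number here means a stronger inhibitor, a higher number a weaker inhibitor:

compound 1 `CCn1cc(C(=O)N2N=C(c3cc4ccccc4o3)CC2c2ccc(N(C)C)cc2)c(=O)c2ccc(C)nc21` — > 206000 nM
compound 2 `CCn1cc(C(=O)N2N=C(c3cc4ccccc4o3)CC2c2ccc(Cl)cc2)c(=O)c2ccc(C)nc21` — > 160000 nM
compound 3 `CCn1cc(C(=O)N2N=C(c3cc4ccccc4o3)CC2c2ccccc2Cl)c(=O)c2ccc(C)nc21` — > 178000 nM

Every value shown in this assay is a limit of the assay, not a number. Compound 3 sits at the limit (the limit of > 178000 nM in this assay, at which 1 of the 3 values shown sits). Compound 2 sits at the limit (the limit of > 160000 nM in this assay, at which 1 of the 3 values shown sits). Compound 1 sits at the limit (the limit of > 206000 nM in this assay, at which 1 of the 3 values shown sits). Compound 3 therefore stands only on a limit, and the two further values it could be compared with are limits as well.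

The steps among the measured compounds carry no readable size: a step that the two limits leave unreadable from compound 1 to compound 2, a step that the two limits leave unreadable from compound 1 to compound 3 and a step that the two limits leave unreadable from compound 2 to compound 3 all stay hidden behind the two limits.

Compound 4 `CCn1cc(C(=O)N2N=C(c3cc4ccccc4o3)CC2/C=C/c2ccccc2)c(=O)c2ccc(C)nc21` differs from compound 3 by 2-phenylethenyl in place of 2-chlorophenyl on a saturated ring carbon. The three hidden steps are the only ones bearing on this change, and none of them gives a direction or a size. Within the saturated-ring substituent, the three measured variations left the read-out at its limit each time, so the expectation for this assay is no step beyond the scatter, expressed as a step that the limit leaves unreadable from compound 3 to compound 4. The value estimated for compound 4 is 190000 nM, within 95000 nM to 380000 nM, most likely reported again only as a limit.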

Compound 4, half-maximal inhibitory concentration: > 168000 nM
Compound 4 ended at the assay's limit (the forecaster's own chance of this, stated with the estimate: 85%); the middle value is on the limit's open side.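

In this assay compound 4 gives > 168000 nM, which is a limit and not a number. Within the data shown here, no step between compound 4 and compound 1, compound 2 or compound 3 can be read. The compounds shown leave open whether changing the group on the saturated ring carbon shifts this read-out at all.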